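The source may hold more compounds than are shown below. What is called first, only, known or untested is meant among the compounds shown, and "the series" means these compounds.

Compound 1 `O=C(CCN1C(=O)CSc2ccccc21)N1CCN(c2ccc(C(F)(F)F)cc2)CC1` gives > 100000 nM in a functional assay (MiaPaCa cells, Homo sapiens) for inhibition, read by sulforhodamine B assay, with a stated time of 48 h (a higher number here means a weaker inhibitor of growth, a lower number a stronger inhibitor of growth), which is a limit of the assay rather than a number. Compound 2 `O=C(CCN1C(=O)CSc2ccccc21)N1CCN(c2ccccc2F)CC1` also reaches only a limit, > 100000 nM in this assay. The step that the two limits leave unreadable from compound 1 to compound 2 cannot be sized because the limit of > 100000 nM in this assay, at which 2 of the 2 values shown sit, holds both of its ends. Compound 2 thus stands at that limit, with no measured number beside it in this series. Compound 3 `O=C(CCN1C(=O)CSc2ccccc21)N1CCN(c2ccccc2)CC1` differs from compound 2 by hydrogen in place of fluoro on an aromatic carbon. No readable measured step bears on this change. Compound 3 is expected to give 150000 nM (range 40000 nM to 600000 nM). The estimated step that the limit leaves unreadable from compound 2 to compound 3 is expected to lie within the scatter, most likely ending again at a limit.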

Compound 3, concentration for 50% growth inhibition: > 100000 nM
Compound 3: only a limit was reported; the forecaster's own chance of this, stated with the estimate: 80%; the middle value is on the limit's open side.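

For the compounds shown here, no step among compound 1, compound 2 and compound 3 can be read, as all three rest on one limit: the limit of > 100000 nM in this assay, at which 3 of the 3 values shown sit. In this assay, as far as these compounds go, it stays open whether 4-(trifluoromethyl)phenyl, 2-fluorophenyl and phenyl differ at all.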